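Swapping hydroxy for ethyl on a series tested for NF-kappa-B inhibition

A few compounds are considered here, and "the series" means these few. Any claim that something is new, unique, unknown or untested is made for them only; others in the source may bear on it.

In an assay on FRT-Jurkat cells for inhibition of nuclear factor NF-kappa-B complex (Homo sapiens), read by flow cytometry, with a stated time of 24 h, tested at 10 uM (on this read-out lower numbers stand for less inhibition and higher numbers for more inhibition at the one concentration tested (going by the name of the read-out)), compound 2 `O=C1CCC(N2C(=O)c3cccc(Nc4ccc(O)cc4)c3C2=O)C(=O)N1` gives 4%, and compound 1 `CC(=O)c1ccc(Nc2cccc3c2C(=O)N(C2CCC(=O)NC2=O)C3=O)cc1` gives 2%; the two numbers lie within the scatter of each other, so neither stands apart. For the measured compounds named here, the only measured step, a number 2 percentage points higher from compound 1 to compound 2 (within the scatter), changes the same aromatic position and shows no effect. Compound 3 `CCc1ccc(Nc2cccc3c2C(=O)N(C2CCC(=O)NC2=O)C3=O)cc1` differs from compound 2 by ethyl in place of hydroxy on an aromatic carbon. Going by the values given here, no step exists for ethyl itself, so the expectation rests on both measured compounds sitting near zero; a step of a number 1 percentage points lower from compound 2 to compound 3 (within the scatter) is estimated, none beyond the scatter. Compound 3 is therefore expected to give about 3%, between -7% and 13%.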

Compound 3, a percentage reported as inhibition, at one concentration (the size of the read-out at that concentration, not a potency): 17%
Beside the measured number, compound 3's estimate is 14 percentage points below it; measured number outside the range, above it.
By their numbers in this assay, from the lowest: compounds 1 and 2 (each within the scatter of the next); then compound 3.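

In this assay, ethyl in place of hydroxy gives a number 13 percentage points higher from compound 2 to compound 3 (beyond the scatter), and ethyl in place of acetyl gives a number 15 percentage points higher from compound 1 to compound 3 (beyond the scatter). The group on this aromatic carbon, para to a large group, can therefore change the read-out, which the swap between hydroxy and acetyl alone did not show. No measurement here explains why ethyl stands apart.

From the compounds shown here alone, whether a longer chain such as propyl would raise the number further remains open. So does what an amine or a carboxylic acid would do at this position.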